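The source may report more compounds than this note shows. Statements on the series, on what has been measured and on what is new or still open speak of the compounds shown alone.

Measured so far in this series:

compound 1 `Nc1nc(Cl)c(-c2cccs2)c(N[C@@H]2C[C@H](CO)[C@@H](O)[C@H]2O)n1` — > 25000 nM, which is a limit of the assay and not a number
compound 2 `CNc1ccc2sc(-c3c(Cl)nc(N)nc3N[C@@H]3C[C@H](CO)[C@@H](O)[C@H]3O)nc2c1` — 20000 nM
compound 3 `Cc1nc(NC(C)C)nc(N[C@@H]2C[C@H](CO)[C@@H](O)[C@H]2O)c1-c1nc2ccccc2s1` — 13000 nM

The read-out is an ADME assay on cells (Homo sapiens) for cytotoxicity, read by polymerase chain reaction, with a stated time of 3 days; a higher number here means that more compound is tolerated, a lower number that less compound is tolerated. For the measured compounds named here, only two numbers stand against it. Compound 3 gives the smaller of the two, but compound 2 lies within the scatter of it, so the two cannot be told apart. For compound 1 the assay reports only (the limit of > 25000 nM in this assay, at which 1 of the 3 values shown sits).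

Compound 4 `Cc1nc(NCCCC(F)(F)F)nc(N[C@@H]2C[C@H](CO)[C@@H](O)[C@H]2O)c1-c1nc2ccccc2s1` is not yet measured. It differs from compound 3 in one place: 4,4,4-trifluorobutyl in place of isopropyl on a nitrogen on an aromatic ring. Going by the values given here, no pair of measured compounds shows this or any single change, so there is no measured step to lean on, and no evidence on what the 4,4,4-trifluorobutyl in place of isopropyl does to tolerance.

With nothing in the data pointing either way, the expected step from compound 3 to compound 4 is a 1.1-fold lower number from compound 3 to compound 4 (0.03 log units; within the scatter), which is within the usual scatter. Compound 4 is therefore estimated at 12000 nM in this assay, with a range from 5000 nM to 25000 nM.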

Compound 4, half-maximal cytotoxic concentration: 3000 nM
Beside the measured number, compound 4's estimate is 4.0-fold (0.60 log units) above it; the whole stated range lies above it.
By their numbers in this assay, from the lowest: compound 4; then compounds 3 and 2 (each within the scatter of the next). At a limit, above all of these: compound 1.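

For the compounds shown here, this position, the nitrogen on an aromatic ring, gives the only single change that can be read so far in this assay, and it is not silent: 4,4,4-trifluorobutyl in place of isopropyl gives a 4.3-fold lower number from compound 3 to compound 4 (0.64 log units; beyond the scatter). The step is modest but lies beyond the scatter, so less compound is tolerated with this chain than with isopropyl on the shared core. Nothing in the data shown bears on what lies behind this step.

The change alters chain length and adds fluorine in one move, so the compounds shown cannot say which of the two goes with the lower number. A plain butyl at this nitrogen would separate the two, and a chain ending in a hydroxyl or an amine would show whether the end of the chain matters.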